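Replacing a benzothiazolyl group with a pyridinylmethoxy group

The compounds below may be only part of what the source reports. "The series", "measured", "known", "first", "only" and "open" are said of these compounds alone.

The measured compounds:
- compound 1 `O=C(O)CCCSCCN1C(=O)CC[C@@H]1/C=C/[C@@H](O)Cc1cccc(N2Cc3ccccc3C2)c1`, 28 nM
- compound 2 `O=C(O)CCCSCCN1C(=O)CC[C@@H]1/C=C/[C@@H](O)Cc1cccc(-c2ccc3[nH]ccc3c2)c1`, 85 nM
- compound 3 `O=C(O)CCCSCCN1C(=O)CC[C@@H]1/C=C/[C@@H](O)Cc1cccc(-c2nc3ccccc3s2)c1`, 3.2 nM

All three were tested in a functional assay on CHO cells for agonist activity at prostaglandin E2 receptor EP4 subtype (Rattus norvegicus), read by cAMP accumulation and immunoassay, with a stated time of 10 min; a higher number here means that more compound is needed for the effect, a lower number that less compound is needed. Compound 3 gives the lowest number of the three: the nearest is compound 1, an 8.8-fold lower number from compound 1 to compound 3 (0.94 log units; beyond the scatter), and the furthest is compound 2, a 27-fold lower number from compound 2 to compound 3 (1.42 log units; beyond the scatter). The group on the aromatic carbon has so far moved the numbers widely, as a 3.0-fold higher number from compound 1 to compound 2 (0.48 log units; beyond the scatter) also shows.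

Compound 4 `O=C(O)CCCSCCN1C(=O)CC[C@@H]1/C=C/[C@@H](O)Cc1cccc(OCc2ccncc2)c1` differs from compound 3 in one place: (pyridin-4-yl)methoxy in place of 1,3-benzothiazol-2-yl on an aromatic carbon. Within the data shown here, none of the measured steps swaps an aromatic bicyclic group for an ether-linked single ring, so only the general sensitivity of this position can be drawn on. Since the two other groups at this position gave higher numbers than compound 3, the account expects compound 4 to give a higher number as well, a 13-fold higher number from compound 3 to compound 4 (1.10 log units; beyond the scatter), with wide uncertainty. The estimate for compound 4 in this assay is 40 nM, between 8 nM and 250 nM.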

Compound 4, half-maximal effective concentration: 46 nM
Estimate against measurement, compound 4: 1.2-fold (0.06 log units) below; the measured number falls inside the stated range.
By their numbers in this assay, from the lowest: compound 3; then compounds 1, 4 and 2 (each within the scatter of the next, the first and the last beyond it).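

The (pyridin-4-yl)methoxy group shows that the position tolerates a single ring linked through an ether, but at a clear cost against the 1,3-benzothiazol-2-yl group, with a 14-fold higher number from compound 3 to compound 4 (1.16 log units; beyond the scatter). That cost brings compound 4 level with the two other groups, with a 1.8-fold lower number from compound 2 to compound 4 (0.27 log units; within the scatter) and a 1.6-fold higher number from compound 1 to compound 4 (0.22 log units; within the scatter), even though compound 1 and compound 2 are separated by a 3.0-fold higher number from compound 1 to compound 2 (0.48 log units; beyond the scatter), so only compound 3 now stands apart from all the others. Nothing shown here explains why the 1,3-benzothiazol-2-yl group stands apart.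

The compounds shown leave open whether the step follows from the ether link or from the single pyridine ring, which a directly attached pyridin-4-yl or a benzyloxy group would help separate. They also leave open whether the sulfur of compound 3 matters, as a 1,3-benzoxazol-2-yl group would test.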